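Replacing Propyl with a Ring-Bearing Amide on the Shared Core

The source may report more compounds than this note shows. Statements on the series, on what has been measured and on what is new or still open speak of the compounds shown alone.

Of the compounds shown here, three built on one shared core have been tested in an assay on membranes from brain for displacement of a labelled ligand from Neuronal acetylcholine receptor; alpha4/beta2 (Rattus norvegicus); a lower number here means a stronger inhibitor, a higher number a weaker inhibitor. Compound 1 `CN1CCC[C@H]1COc1cccnc1I` gives 606 nM, compound 2 `Cc1ccncc1OC[C@@H]1CCCN1C` gives 4.12 nM, and compound 3 `CCCc1cncc(OC[C@@H]2CCCN2C)c1` gives 0.12 nM, the lowest of the three numbers and separated from both others by gaps well beyond the usual scatter. Compound 4 `CN1CCC[C@H]1COc1cncc(C(=O)N2CCCC2)c1` has not yet been measured. It differs from compound 3 in one place: (pyrrolidin-1-yl)carbonyl in place of propyl on an aromatic carbon. For the measured compounds named here, no measured pair shows a change of this kind, so nothing here tells how the assay responds to it. Since the entering group is much larger than the leaving propyl and compound 3 already stands at the low end, the step from compound 3 to compound 4 is expected to go upward, by a 170-fold higher number from compound 3 to compound 4 (2.22 log units; beyond the scatter). Compound 4 is estimated at 20 nM, within 2 nM to 200 nM.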

Compound 4, inhibition constant: 19.9 nM
Beside the measured number, compound 4's estimate is 1.0-fold (0.00 log units) above it; low and high end bracket the measured number.
By their numbers in this assay, from the lowest: compound 3; then compound 2; then compound 4; then compound 1.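

In this assay this aromatic carbon, two atoms from the ring nitrogen, proves sensitive: (pyrrolidin-1-yl)carbonyl in place of propyl gives a 170-fold higher number from compound 3 to compound 4 (2.22 log units; beyond the scatter) as a large change, beyond the scatter. Even so, compound 4 at 19.9 nM keeps a measurable affinity. No measurement at hand explains the change.

From the compounds shown here alone, whether a longer chain such as butyl would behave like propyl stays open. Also open, going by these compounds, is whether the carbonyl or the ring drives the step, which a pyrrolidin-1-ylmethyl group, holding the ring without the carbonyl, could help separate.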